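The source may hold more compounds than are shown below. What is called first, only, known or untested is meant among the compounds shown, and "the series" means these compounds.

Compound 1 `CC(C#CCn1ccnc1)N1CCCC1=O` and compound 2 `Cc1cncn1CC#CC(C)N1CCCC1=O` share one core, while compound 3 `CN1CCN(CC#CCn2ccnc2)C1=O` and the unmeasured compound 4 `Cc1cncn1CC#CCN1CCN(C)C1=O` share another; the difference between the two cores is not broken down here. In a functional assay on the whole organism for agonist activity, with Mus musculus as the target (on this read-out lower numbers stand for an effect already at smaller amounts and higher numbers for an effect only at larger amounts of compound), compound 1 gives > 100 mg/kg, which is a limit of the assay and not a number. Compound 2 likewise gives only a limit, > 100 mg/kg. For the measured compounds named here, compound 3 gives 1.4 mg/kg in this assay, the only number among the three. The change from compound 1 to compound 2 is methyl in place of hydrogen on an aromatic carbon, and its step is a step that the two limits leave unreadable from compound 1 to compound 2, because of the limit of > 100 mg/kg in this assay, at which 2 of the 3 values shown sit. The same change, (methyl in place of hydrogen on an aromatic carbon), leads from compound 3 to compound 4. Compound 4 is expected to give 2 mg/kg in this assay, with a range from 0.6 mg/kg to 8 mg/kg. This estimate means a step of a 1.4-fold higher number from compound 3 to compound 4 (0.15 log units; within the scatter), resting on compound 3 with 1.4 mg/kg and on the fact that the earlier step gave no readable size.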

Compound 4, dose for half-maximal effect: 14 mg/kg
Estimate against measurement, compound 4: 7.0-fold (0.85 log units) below; measured number above the stated range.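

In this assay, methyl in place of hydrogen on an aromatic carbon gives a 10-fold higher number from compound 3 to compound 4 (1.00 log units; beyond the scatter), so on the core of compound 3 the change has a readable size, beyond the scatter. This is the only readable instance of the change among the compounds shown, and it gives no size for the core of compound 1. The step from compound 1 to compound 2 cannot be read, so the data do not show whether the change carries over between the two cores, because both of these compounds give only a limit and not a number: the limit of > 100 mg/kg in this assay, at which 2 of the 4 values shown sit.

On these data alone, an ethyl or a hydroxymethyl group on the same aromatic carbon remains open. So does the question of whether either group would give a readable step on the core of compound 1.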